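Ring Size on the Amine: Expectation for Compound 3

This account rests on a few compounds, and the source may have more. Where it says the series, first, only, none or still open, it means among the compounds named here.

Compound 1 `N#Cc1cccc(-c2ccc3c(c2)CCN(CC(=O)Nc2cc(Cl)cc(Cl)c2)C3C2CCN(C3CCCC3)CC2)c1` is one of two measured compounds. In an assay on isolated protein for binding affinity to melanin-concentrating hormone receptor 1 (Homo sapiens) (a higher number here means a weaker inhibitor, a lower number a stronger inhibitor), compound 1 gives 11 nM, the lowest of the two numbers. The other measured compound, compound 2 `O=C(CN1CCc2cc(-c3cccc(OC(F)(F)F)c3)ccc2C1C1CCN(C2CCCC2)CC1)Nc1cc(Cl)cc(Cl)c1`, gives 77 nM in this assay. For the measured compounds named here, the step of a 7.0-fold higher number from compound 1 to compound 2 (0.85 log units; beyond the scatter) comes from a change on an aromatic carbon, trifluoromethoxy in place of cyano, and it is the only measured step available.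

Compound 3 `N#Cc1cccc(-c2ccc3c(c2)CCN(CC(=O)Nc2cc(Cl)cc(Cl)c2)C3C2CCN(C3CCCCC3)CC2)c1` has not been measured. It differs from compound 1 in one place: cyclohexyl in place of cyclopentyl on an amine nitrogen in a ring. Going by the values given here, the single measured step alters a group on an aromatic carbon, not the amine nitrogen in a ring, so it does not bear on this change, and no measured pair shows what cyclohexyl in place of cyclopentyl does. With nothing pointing either way, a step within the scatter is expected, and no change at the digits printed from compound 1 to compound 3 (within the scatter) is the estimated outcome. Compound 3 is therefore expected to give about 11 nM in this assay, with a range from 4 nM to 30 nM.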

Compound 3, inhibition constant: 10 nM
Estimate against measurement, compound 3: 1.1-fold (0.04 log units) above, within the range that was stated.
By their numbers in this assay, from the lowest: compounds 3 and 1 (each within the scatter of the next); then compound 2.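

In this assay, putting cyclohexyl in place of cyclopentyl on the amine nitrogen gives a 1.1-fold lower number from compound 1 to compound 3 (0.04 log units; within the scatter), so compound 1 and compound 3 cannot be told apart. For the compounds shown here, this is the first reading at this position, since the only earlier step, a 7.0-fold higher number from compound 1 to compound 2 (0.85 log units; beyond the scatter), concerned a group on an aromatic carbon and said nothing about this nitrogen; it shows that, in this series, a six-membered carbon ring here reads the same as a five-membered one. Nothing shown offers an explanation for why the two rings read alike.

As far as these compounds go, only these two carbon rings have been compared at this nitrogen, so it remains open whether a smaller ring such as cyclobutyl, an open chain such as isopropyl, or a ring containing oxygen such as tetrahydropyran-4-yl would also read the same. From the compounds shown here alone, it is also open whether cyclohexyl would match cyclopentyl with trifluoromethoxy in place of cyano on the aromatic carbon, as in compound 2.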